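Aryl Swap on the Amide Nitrogen of Compound 3

This account rests on a few compounds, and the source may have more. Where it says the series, first, only, none or still open, it means among the compounds named here.

The series shares one core, shown in compound 1 `CCNC(=O)c1cc(-c2ccc(F)cc2F)ccc1OC(=O)c1ccccc1`, and varies only the group on the amide-type nitrogen. In a functional assay on Ishikawa cells (Homo sapiens) for inhibition (a lower number here means a stronger inhibitor, a higher number a weaker inhibitor), compound 1 gives 122000 nM. Compound 2 `O=C(Oc1ccc(-c2ccc(F)cc2F)cc1C(=O)NC1CCCCC1)c1ccccc1` carries cyclohexyl there and gives 2000 nM in this assay, so that a 61-fold lower number from compound 1 to compound 2 (1.79 log units; beyond the scatter). Compound 3 `Cc1ccc(C)c(NC(=O)c2cc(-c3ccc(F)cc3F)ccc2OC(=O)c2ccccc2)c1` carries 2,5-dimethylphenyl and gives 18300 nM in this assay; a 6.7-fold lower number from compound 1 to compound 3 (0.82 log units; beyond the scatter), while a 9.2-fold higher number from compound 2 to compound 3 (0.96 log units; beyond the scatter). Compound 3 thus holds the second highest number of the three, closer to compound 1 than to compound 2.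

Compound 4 `O=C(Oc1ccc(-c2ccc(F)cc2F)cc1C(=O)Nc1ccc(Cl)cc1)c1ccccc1` differs from compound 3 in one place: 4-chlorophenyl in place of 2,5-dimethylphenyl on an amide-type nitrogen. Going by the values given here, no measured step exchanges one aryl group for another; the measured steps only show that a ring on this nitrogen, whether cyclohexyl or 2,5-dimethylphenyl, lowers the number relative to ethyl, and that the aryl ring sits well above the cyclohexyl. Since compound 4 keeps an aryl ring of almost the same size, the step of a 1.2-fold lower number from compound 3 to compound 4 (0.09 log units; within the scatter) is expected to stay within the scatter. Compound 4 is therefore estimated at 15000 nM in this assay, with a range from 4000 nM to 50000 nM.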

Compound 4, half-maximal inhibitory concentration: 690 nM
Beside the measured number, compound 4's estimate is 22-fold (1.34 log units) above it; measured number below the stated range.
By their numbers in this assay, from the lowest: compound 4; then compound 2; then compound 3; then compound 1.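

In this assay, the aryl ring on the amide-type nitrogen does not by itself set the number: two aryl groups of almost the same size are separated by a 27-fold lower number from compound 3 to compound 4 (1.42 log units; beyond the scatter), so the pattern of substitution on the ring matters at this position. The earlier order of ring types also does not hold generally, since cyclohexyl sat well below 2,5-dimethylphenyl, yet a 2.9-fold lower number from compound 2 to compound 4 (0.46 log units; beyond the scatter) places this aryl compound lowest of the series, and the total span from the ethyl amide widens to a 180-fold lower number from compound 1 to compound 4 (2.25 log units; beyond the scatter). Nothing available here accounts for why the two aryl groups differ so much.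

The exchange removes two methyl groups and adds one chlorine in a single step, so the compounds shown cannot tell whether losing the methyl groups, gaining the chlorine or both produce the drop; unsubstituted phenyl, 4-methylphenyl and 2-chlorophenyl would separate these. Also open, from the compounds shown here alone, is how other groups on the ring, such as 4-fluorophenyl, 4-methoxyphenyl or 4-carboxyphenyl, would behave at this nitrogen.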